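A few compounds are considered here, and "the series" means these few. Any claim that something is new, unique, unknown or untested is made for them only; others in the source may bear on it.

In an ADME assay on the whole organism (plasma, strain CD-1) for pharmacokinetics, with Mus musculus as the target, at a dose of 30 mg/kg by the oral route (a lower number here means less compound in the circulation, a higher number more compound in the circulation at the dose given), the two measured compounds gave:
compound 1 `CCCS(=O)(=O)Nc1ccc(F)c(C(=O)Nc2cnc3[nH]ncc3c2)c1F`: 40000 ng.h/mL
compound 2 `CCCS(=O)(=O)Nc1ccc(F)c(C(=O)Nc2cnc3[nH]nc(N(C)C)c3c2)c1F`: 1090 ng.h/mL

Compound 2 stands lowest of these two numbers, separated from compound 1 by a 37-fold lower number from compound 1 to compound 2 (1.56 log units; beyond the scatter). Compound 3 `CCCS(=O)(=O)Nc1ccc(F)c(C(=O)Nc2cnc3[nH]nc(Br)c3c2)c1F` differs from compound 2 in one place: bromo in place of dimethylamino on an aromatic carbon. Among the measured compounds shown here, only that one large step bears on this change, and it says nothing directly about bromo. On these data alone, because a 37-fold lower number from compound 1 to compound 2 (1.56 log units; beyond the scatter) accompanied the arrival of the dimethylamino group that now leaves, the number is expected to move back up, though how far bromo allows this is unknown. Compound 3 is therefore expected to give 8000 ng.h/mL (range 2000 ng.h/mL to 30000 ng.h/mL), an expected step of a 7.3-fold higher number from compound 2 to compound 3 (0.87 log units; beyond the scatter).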

Compound 3, area under the concentration-time curve in the Mus musculus assay: 52500 ng.h/mL
Compound 3: middle estimate off by 6.6-fold (0.82 log units), on the low side, outside the stated range (above it).
By their numbers in the Mus musculus assay, from the lowest: compound 2; then compounds 1 and 3 (each within the scatter of the next).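

In the Mus musculus assay replacing dimethylamino with bromo gives a 48-fold higher number from compound 2 to compound 3 (1.68 log units; beyond the scatter) and bromo in place of hydrogen gives a 1.3-fold higher number from compound 1 to compound 3 (0.12 log units; within the scatter) so among these three groups only dimethylamino goes with a low number. In a physicochemical assay for solubility, read by HPLC, in phosphate buffer, with a stated time of 24 h, at pH 6.5 (on this read-out higher numbers stand for higher solubility and lower numbers for lower solubility), compound 2 gives 290 ug/mL and compound 3 gives 1 ug/mL so the change from dimethylamino to bromo runs the opposite way, and in this pair a high level in the circulation after oral dosing did not require high solubility: the measured solubility of compound 2, 290 ug/mL, and of compound 3, 1 ug/mL, a 290-fold lower number (2.46 log units; beyond the scatter).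

On these data alone, whether a methylamino or chloro group on this aromatic carbon could combine a high circulating level with good solubility remains open.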